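The source may report more compounds than this note shows. Statements on the series, on what has been measured and on what is new or still open speak of the compounds shown alone.

Compound 1 `CCCCCCCCCCCCCCCCCCNC(=O)[C@@H](NC(=O)c1ccccc1)[C@@H](C)O` and compound 2 `CCCCCCCCCCCCCCCCCCNC(=O)[C@@H](NC(=O)c1cccs1)[C@@H](C)O` share a long-chain amide core. In a functional assay on SW-620 cells (Homo sapiens) for cytotoxicity, read by MTT assay, with a stated time of 48 h (a lower number here means a stronger inhibitor, a higher number a weaker inhibitor), compound 1 gives 200000 nM, and compound 2 gives 200000 nM; the step of no change at the digits printed from compound 1 to compound 2 (within the scatter) shows that compound 2 stands level with compound 1. Compound 3 `CCCCCCCCCCCCCCCCCCNC(=O)[C@@H](NC(=O)c1cc2ccccc2[nH]1)[C@@H](C)O` differs from compound 2 by 1H-indol-2-yl in place of thiophen-2-yl on a carbonyl carbon. Going by the values given here, the only measured step, no change at the digits printed from compound 1 to compound 2 (within the scatter), was flat, so in this assay he expects compound 3 to stay near compound 2, with the step of a 1.3-fold lower number from compound 2 to compound 3 (0.12 log units; within the scatter) not beyond the scatter. His estimate for compound 3 is 150000 nM, in the range 40000 nM to 300000 nM.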

Compound 3, half-maximal inhibitory concentration: 23600 nM
Compound 3: middle estimate off by 6.4-fold (0.80 log units), on the high side; measured number outside the range, below it.
By their numbers in this assay, from the lowest: compound 3; then compounds 1 and 2 (each within the scatter of the next).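

In this assay, this place on the carbonyl carbon turns out not to be indifferent to the ring it carries: 1H-indol-2-yl gives an 8.5-fold lower number from compound 2 to compound 3 (0.93 log units; beyond the scatter) and an 8.5-fold lower number from compound 1 to compound 3 (0.93 log units; beyond the scatter). Phenyl and thiophen-2-yl had stood level, so only the group with an added six-membered aromatic ring and a hydrogen-bond donor moved the number. Nothing given here accounts for this step. Still open, as far as these compounds go, is whether the added ring alone suffices, as a naphthalen-2-yl or benzofuran-2-yl group would show, or whether the ring nitrogen with its hydrogen is needed. Also open, from the compounds shown here alone, is whether the lower number survives a shorter chain.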